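This account rests on a few compounds, and the source may have more. Where it says the series, first, only, none or still open, it means among the compounds named here.

Measured so far in a functional assay on Shh Light II cells (Mus musculus) for inhibition, read by a luciferase reporter; on this read-out lower numbers stand for stronger inhibition and higher numbers for weaker inhibition:
compound 1 `O=C(Nc1ccccc1Cl)N1CCC(c2nc(-c3ccc4ccccc4n3)no2)CC1` gives 510 nM
compound 2 `O=C(NC1CC[S+]([O-])CC1)N1CCC(c2nc(-c3ccc4ccccc4n3)no2)CC1` gives 850 nM
compound 3 `O=C(OC1CCCCC1)N1CCC(c2nc(-c3ccc4ccccc4n3)no2)CC1` gives 580 nM

These three compounds share one core and differ only in the group on a carbonyl carbon. Compound 3, at 580 nM, lies within the scatter of both other compounds. The steps that reach it are a 1.1-fold higher number from compound 1 to compound 3 (0.06 log units; within the scatter) and a 1.5-fold lower number from compound 2 to compound 3 (0.17 log units; within the scatter), and the remaining pair shows a 1.7-fold higher number from compound 1 to compound 2 (0.22 log units; within the scatter). None of the three steps goes beyond the scatter, although the group in that place differs considerably among them.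

The next compound is compound 4 `COc1ccccc1N(C)C(=O)N1CCC(c2nc(-c3ccc4ccccc4n3)no2)CC1`, which carries (2-methoxyphenyl)(methyl)amino in place of cyclohexyloxy on a carbonyl carbon. The most relevant precedent is compound 1, which holds (2-chlorophenyl)amino in that place, since a 1.1-fold higher number from compound 1 to compound 3 (0.06 log units; within the scatter) is the measured exchange of such an aromatic group for cyclohexyloxy. Within the data shown here, no measured compound has (2-methoxyphenyl)(methyl)amino itself, so the precedent is only partial and the range has to stay wide. On this basis, no shift beyond the scatter is expected, and the expected result is a 1.0-fold higher number from compound 3 to compound 4 (0.01 log units; within the scatter). For compound 4 the estimated value is 600 nM, with an expected range of 220 nM to 1700 nM.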

Compound 4, half-maximal inhibitory concentration: 3100 nM
Estimate against measurement, compound 4: 5.2-fold (0.71 log units) below, and the stated range ends below it.
By their numbers in this assay, from the lowest: compounds 1, 3 and 2 (each within the scatter of the next); then compound 4.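

In this assay, among these compounds, the group on this carbonyl carbon had so far changed widely with no step beyond the scatter, but compound 4 now separates from all three earlier compounds (a 5.3-fold higher number from compound 3 to compound 4 (0.73 log units; beyond the scatter); a 3.6-fold higher number from compound 2 to compound 4 (0.56 log units; beyond the scatter); a 6.1-fold higher number from compound 1 to compound 4 (0.78 log units; beyond the scatter)). Among the compounds shown here, the step from compound 1 is the most telling, since both compounds carry an aromatic ring on an amino group in this place, so the presence of such a ring does not by itself keep the number near those of the earlier compounds: (2-methoxyphenyl)(methyl)amino behaves differently here from (2-chlorophenyl)amino, and compound 4 also lacks the amide hydrogen that compound 1 has. Nothing available explains this rise in the number.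

The compounds shown leave open whether the added methyl or the methoxy in place of the chlorine accounts for the step from compound 1, a question that (2-methoxyphenyl)amino or (2-chlorophenyl)(methyl)amino in this place would separate. They also leave open whether a methyl on the amino group has a similar effect without an aromatic ring, as in cyclohexyl(methyl)amino.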